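Working notes: nitro-to-chloro exchange in a small aminopyrimidine set

The compounds below may be only part of what the source reports. "The series", "measured", "known", "first", "only" and "open" are said of these compounds alone.

Measured compounds:
- compound 1, `Cc1cc(Nc2cc(N3CCN(C)CC3)nc(Nc3ccc([N+](=O)[O-])cc3)n2)n[nH]1`, in a functional assay on MCF7 cells (Homo sapiens) for antiproliferative activity, read by CCK-8 assay, with a stated time of 72 h (on this read-out higher numbers stand for weaker inhibition and lower numbers for stronger inhibition), compound 1 gives 424 nM
- compound 2, `Cc1cc(Nc2cc(N3CCN(C)CC3)nc(Nc3ccc(Cl)cc3)n2)n[nH]1`, compound 2 gives 840 nM
- compound 3, `Cc1cc(Nc2cc(N3CCN(C)CC3)nc(Nc3cccc([N+](=O)[O-])c3)n2)n[nH]1`, compound 3 gives 642 nM

All three share one core and differ only in the aryl group carried on the anilino nitrogen. Going from compound 1 to compound 2 the change is chloro in place of nitro on an aromatic carbon and the step is a 2.0-fold higher number from compound 1 to compound 2 (0.30 log units; within the scatter). The two cores of compound 1 and compound 3 differ by 3-nitrophenyl in place of 4-nitrophenyl on a nitrogen on an aromatic ring, with a step of a 1.5-fold higher number from compound 1 to compound 3 (0.18 log units; within the scatter). Between compound 2 and compound 3 the step is a 1.3-fold lower number from compound 2 to compound 3 (0.12 log units; within the scatter). None of these three steps leaves the usual scatter, so no ordering among compound 1, compound 2 and compound 3 is claimed.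

Compound 4, `Cc1cc(Nc2cc(N3CCN(C)CC3)nc(Nc3cccc(Cl)c3)n2)n[nH]1`, is not yet measured. It differs from compound 3 by chloro in place of nitro on an aromatic carbon. Among the compounds with values here, this is the same kind of change as the one from compound 1 to compound 2, but not the same: in that pair the place is para to a large group, whereas here the place is meta to a large group.

Within the data shown here, the step from compound 3 to compound 4 is estimated as a 1.9-fold higher number from compound 3 to compound 4 (0.27 log units; within the scatter), resting on the one measured example of this kind of change, a 2.0-fold higher number from compound 1 to compound 2 (0.30 log units; within the scatter), read together with the small spread between compound 2 and compound 3. On that basis compound 4 is expected to give about 1200 nM in this assay, with a plausible range from 500 nM to 2900 nM.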

Compound 4, half-maximal inhibitory concentration: 436 nM
Estimate against measurement, compound 4: 2.8-fold (0.44 log units) above, outside the stated range (below it).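

Chloro in place of nitro does not carry from the core of compound 1 to the core of compound 3 as one fixed step in this assay, where the new step reads (a 1.5-fold lower number from compound 3 to compound 4 (0.17 log units; within the scatter)) and the gap to the earlier one is beyond the scatter: the same change on two cores in this assay, a 2.0-fold higher number (0.30 log units; within the scatter) from compound 1 to compound 2 and a 1.5-fold lower number (0.17 log units; within the scatter) from compound 3 to compound 4, 2.9-fold (0.46 log units) apart, beyond the scatter of two such steps

Each of the two steps on its own stays within the scatter, so this does not show that the exchange moves the number in a given direction on either core, and a single pair of cores gives no rule for further cores in the series. The other new steps (a 1.9-fold lower number from compound 2 to compound 4 (0.28 log units; within the scatter)) and (a 1.0-fold higher number from compound 1 to compound 4 (0.01 log units; within the scatter)) also stay within the scatter, so no ordering among the four compounds is claimed, and the 3-chlorophenyl and 4-chlorophenyl compounds are not separated.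

The compounds shown leave open whether the gap between the two steps would recur if a nitrile, a methoxy group or a trifluoromethyl group stood in place of nitro. They also leave open whether it would recur with an ethyl group in place of the methyl group on the shared core.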